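From 4-fluorophenyl to 2-chlorophenyl on an aromatic nitrogen

This account rests on a few compounds, and the source may have more. Where it says the series, first, only, none or still open, it means among the compounds named here.

Measured in a functional assay on LoVo cells (Homo sapiens) for inhibition, read by MTT assay, with a stated time of 24 h (a higher number here means a weaker inhibitor, a lower number a stronger inhibitor), so far
compound 1 `CC1(C)[C@H]2CC[C@]1(C)N(Cc1cn(-c3ccccc3Br)nn1)C(=O)C2` gives 60 nM
compound 2 `CC1(C)[C@H]2CC[C@]1(C)N(Cc1cn(-c3ccccc3F)nn1)C(=O)C2` gives 40 nM
compound 3 `CC1(C)[C@H]2CC[C@]1(C)N(Cc1cn(-c3ccc(F)cc3)nn1)C(=O)C2` gives 40 nM

In this assay compound 3 at 40 nM stands level with compound 2 and within the scatter of compound 1. Compound 4 `CC1(C)[C@H]2CC[C@]1(C)N(Cc1cn(-c3ccccc3Cl)nn1)C(=O)C2` carries 2-chlorophenyl in place of 4-fluorophenyl on an aromatic nitrogen, a change set out as 2-chlorophenyl in place of 4-fluorophenyl on an aromatic nitrogen in full. The measured steps bearing on it are small, namely no change at the digits printed from compound 2 to compound 3 (within the scatter) and a 1.5-fold lower number from compound 1 to compound 2 (0.18 log units; within the scatter) as well as a 1.5-fold lower number from compound 1 to compound 3 (0.18 log units; within the scatter) and none lies beyond the scatter. No step beyond the scatter is therefore expected in this assay for this change. The step expected is a 1.3-fold higher number from compound 3 to compound 4 (0.10 log units; within the scatter) and it stays within the scatter. Compound 4 is estimated at 50 nM with a range from 28 nM to 90 nM as its expected span.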

Compound 4, half-maximal inhibitory concentration: 190 nM
Estimate against measurement, compound 4: 3.8-fold (0.58 log units) below; measured number above the stated range.
By their numbers in this assay, from the lowest: compounds 2, 3 and 1 (each within the scatter of the next); then compound 4.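

In this assay, among these compounds, 2-chlorophenyl stands apart from the other aryl groups, with a 4.8-fold higher number from compound 3 to compound 4 (0.68 log units; beyond the scatter) and a 4.8-fold higher number from compound 2 to compound 4 (0.68 log units; beyond the scatter) as well as a 3.2-fold higher number from compound 1 to compound 4 (0.50 log units; beyond the scatter) where the earlier compounds had stayed within the scatter of one another. On this aromatic carbon, chloro therefore separates from both fluoro and bromo, so the numbers do not run smoothly from one halogen to the next. Nothing available accounts for this departure.

Still open, as far as these compounds go, is whether 4-chlorophenyl would stand with compound 3 or with compound 4. Also open, from the compounds shown here alone, is how a methyl, methoxy or amine group on that same carbon would compare.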